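The source may hold more compounds than are shown below. What is called first, only, known or untested is meant among the compounds shown, and "the series" means these compounds.

Series notes. Compound 1 `COc1ccccc1CSc1nc2ccccc2n1CC(=O)O` gives 1100 nM in an assay on HEK293 cells for displacement of a labelled ligand from prostaglandin D2 receptor 2 (Homo sapiens); a lower number here means a stronger inhibitor, a higher number a weaker inhibitor. Within the data shown here, compound 2 `COc1ccc(C(=O)OC(C)C)cc1CSc1nc2ccccc2n1CC(=O)O` gives 150 nM and stands lowest of the two numbers; the change a 7.3-fold lower number from compound 1 to compound 2 (0.87 log units; beyond the scatter) is the only step measured so far. Compound 3 `COc1ccc(C(C)O)cc1CSc1nc2ccccc2n1CC(=O)O` carries the change (1-hydroxyethyl in place of isopropoxycarbonyl on an aromatic carbon), on the aromatic carbon that is meta to a large group and para to a methoxy group. The step from compound 1 to compound 2 bears on it in reverse: removing the isopropoxycarbonyl cost that gain, and 1-hydroxyethyl is a smaller replacement. A rise is therefore expected, a 2.7-fold higher number from compound 2 to compound 3 (0.43 log units; beyond the scatter), short of the full return to compound 1. Compound 3 is estimated at 400 nM, between 150 nM and 1100 nM.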

Compound 3, half-maximal inhibitory concentration: 2200 nM
Compound 3: middle estimate off by 5.5-fold (0.74 log units), on the low side; the whole stated range lies below it.
By their numbers in this assay, from the lowest: compound 2; then compounds 1 and 3 (each within the scatter of the next).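

Isopropoxycarbonyl's gain at this aromatic carbon does not carry over to the smaller 1-hydroxyethyl: the exchange gives a 15-fold higher number from compound 2 to compound 3 (1.17 log units; beyond the scatter) and marks this as a large change. Against hydrogen at the same carbon, the reading is a 2.0-fold higher number from compound 1 to compound 3 (0.30 log units; within the scatter) and 1-hydroxyethyl cannot be told apart from hydrogen here, so none of the gain remains. No measurement at hand accounts for the gap between these two groups. Open, as far as these compounds go, is whether the gain needs the whole ester: a carboxylic acid, a methyl ester or an amide on this carbon would separate the carbonyl from the isopropyl part.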